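Working notes: compound 2 to compound 3, outer ring halogen

This account rests on a few compounds, and the source may have more. Where it says the series, first, only, none or still open, it means among the compounds named here.

Measured so far:
compound 1 `O=C1NC(=O)C(Cc2ccc(Oc3ccccc3)cc2)S1` gives 307 nM in a functional assay for agonist activity at Free fatty acid receptor 1 (Homo sapiens), read by FLIPR, in the presence of a further agent that is not named here; a lower number here means that less compound is needed, a higher number that more compound is needed for the effect
compound 2 `O=C1NC(=O)C(Cc2ccc(Oc3ccc(F)cc3)cc2)S1` gives 480 nM in this assay

Compound 2 carries the higher of the two numbers, but the step of a 1.6-fold higher number from compound 1 to compound 2 (0.19 log units; within the scatter) lies within the scatter, so the two are not told apart.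

Compound 3 `O=C1NC(=O)C(Cc2ccc(Oc3ccccc3Cl)cc2)S1` differs from compound 2 by 2-chlorophenyl in place of 4-fluorophenyl on an oxygen on an aromatic ring. Among the compounds with values here, the only measured step touching this ring is a 1.6-fold higher number from compound 1 to compound 2 (0.19 log units; within the scatter), a fluoro added to an aromatic carbon, and it stayed within the scatter. Within the data shown here, no measured step covers a chloro, nor a group at the place that 2-chlorophenyl names. No change beyond the scatter is therefore expected in this assay; the expected step is a 1.1-fold lower number from compound 2 to compound 3 (0.03 log units; within the scatter). Compound 3 is estimated at 450 nM, range 150 nM to 1400 nM.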

Compound 3, half-maximal effective concentration: 1190 nM
The estimate for compound 3 lay 2.6-fold (0.42 log units) below the measured number; low and high end bracket the measured number.
By their numbers in this assay, from the lowest: compounds 1 and 2 (each within the scatter of the next); then compound 3.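

In this assay, 2-chlorophenyl in place of 4-fluorophenyl raises the number (a 2.5-fold higher number from compound 2 to compound 3 (0.39 log units; beyond the scatter)), and chloro in place of hydrogen on the same outer ring does so too (a 3.9-fold higher number from compound 1 to compound 3 (0.59 log units; beyond the scatter)). This ring therefore does respond to substitution, which the fluoro step (a 1.6-fold higher number from compound 1 to compound 2 (0.19 log units; within the scatter)) did not show. No measurement here gives a reason for the rise.

As far as these compounds go, whether the rise goes with the chloro itself or with the place named in 2-chlorophenyl stays open. So does how a methyl or methoxy group would read at that place.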